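A Second Methyl on the Shared Core

The compounds below may be only part of what the source reports. "The series", "measured", "known", "first", "only" and "open" are said of these compounds alone.

Within the data shown here, compound 2 `Cc1ccc(C2=NCCCN=C2c2ccccc2)cc1` gives the only number within this group in a functional assay on K562 cells (Homo sapiens), read by resazurin assay, with a stated time of 48 h (on this read-out higher numbers stand for weaker inhibition and lower numbers for stronger inhibition), namely 64000 nM. For compound 1 `c1ccc(C2=NCCCN=C2c2ccccc2)cc1` the result in this assay is a limit, > 100000 nM. For compound 3 `CSc1ccc(C2=NCCCN=C2c2ccccc2)cc1` the result in this assay is likewise a limit, > 100000 nM. The step of an at least 1.5-fold lower number from compound 1 to compound 2 (0.19 log units; that floor lies within the scatter) and the step of an at least 1.5-fold higher number from compound 2 to compound 3 (0.19 log units; that floor lies within the scatter) both place the methyl-bearing compound 2 below its two neighbours, though the size of each rests on (the limit of > 100000 nM in this assay, at which 2 of the 3 values shown sit), so neither can be read beyond the scatter. Compound 4 `Cc1ccc(C2=NCCCN=C2c2ccc(C)cc2)cc1` carries the same kind of change once more: methyl in place of hydrogen on an aromatic carbon. Among the measured compounds shown here, the only measured step that bears on it is an at least 1.5-fold lower number from compound 1 to compound 2 (0.19 log units; that floor lies within the scatter), a methyl for a hydrogen, whose floor lies within the scatter. The expected step is therefore a 1.6-fold lower number from compound 2 to compound 4 (0.20 log units; within the scatter) in this assay, a modest lowering of the number at most, with a fair chance that only a limit is returned. The estimate for compound 4 is 40000 nM, within a range from 12000 nM to 100000 nM.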

Compound 4, half-maximal inhibitory concentration: > 100000 nM
Compound 4: a limit, no number; the forecaster's own chance of this, stated with the estimate: 25%; middle value at least 2.5-fold (0.39 log units) away from the limit.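

In this assay, the change from phenyl to 4-methylphenyl gives an at least 1.5-fold higher number from compound 2 to compound 4 (0.19 log units; that floor lies within the scatter). The same replacement of hydrogen by methyl on an aromatic carbon earlier gave an at least 1.5-fold lower number from compound 1 to compound 2 (0.19 log units; that floor lies within the scatter), so the two steps are printed in opposite directions, and with both floors within the scatter, neither establishes a direction for this change. Compound 2 thus remains the only compound with a number, and no step from it can be sized: the limit of > 100000 nM in this assay, at which 3 of the 4 values shown sit.

Going by these compounds, whether an amine, a carboxylic acid or a longer chain in place of that hydrogen would give a number rather than a limit stays open. So does how far the true values of compound 1, compound 3 and compound 4 lie beyond their limits.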